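The compounds below may be only part of what the source reports. "The series", "measured", "known", "first", "only" and "open" are said of these compounds alone.

Measured compounds:

Compound 1, `CCCn1c(=O)[nH]c2nc(-c3ccc(S(=O)(=O)N4CCN(c5ccc(F)cc5)CC4)cc3)[nH]c2c1=O`, gives 38% in an assay on CHO cells for displacement of a labelled ligand from adenosine receptor A3 (Homo sapiens), read by scintillation counting, with a stated time of 45 min, tested at 1 uM, in the presence of a further agent that is not named here; a higher number here means more inhibition at the concentration tested (going by the name of the read-out), a lower number less inhibition.
Compound 2, `CCCn1c(=O)[nH]c2nc(-c3ccc(S(=O)(=O)N4CCN(c5ccc(Cl)cc5F)CC4)cc3)[nH]c2c1=O`, gives 14%.
Compound 3, `CCCn1c(=O)[nH]c2nc(-c3ccc(S(=O)(=O)N4CCN(C)CC4)cc3)[nH]c2c1=O`, gives 7%.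

Compound 3 shows the lowest number of the three, though its gap to compound 2 lies within the scatter; only its gap to compound 1 is clearly beyond it. Compound 4, `CCCn1c(=O)[nH]c2nc(-c3ccc(S(=O)(=O)N4CCN(c5ccccc5Br)CC4)cc3)[nH]c2c1=O`, has not yet been measured. It differs from compound 3 in one place: 2-bromophenyl in place of methyl on an amine nitrogen in a ring.

Among the compounds with values here, two measured steps bear on this change, both putting methyl in place of an aryl group on the same ring nitrogen. The step of a number 31 percentage points lower from compound 1 to compound 3 (beyond the scatter) was large, while the step of a number 7 percentage points lower from compound 2 to compound 3 (within the scatter) stayed within the scatter. Going the other way, from methyl to an aryl group, the numbers therefore rose by somewhere between nothing meaningful and a large amount. Since 2-bromophenyl, like 4-chloro-2-fluorophenyl in compound 2, carries a halogen on the aryl ring, a modest rise is expected, a number 9 percentage points higher from compound 3 to compound 4 (within the scatter). Compound 4 is thus estimated at 16%, with a likely range from 4% to 34%.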

Compound 4, a percentage reported as inhibition, at one concentration (the size of the read-out at that concentration, not a potency): 20%
Compound 4: middle estimate off by 4 percentage points, on the low side; low and high end bracket the measured number.
By their numbers in this assay, from the lowest: compounds 3, 2 and 4 (each within the scatter of the next, the first and the last beyond it); then compound 1.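

Putting 2-bromophenyl in place of methyl on the ring nitrogen gives a number 13 percentage points higher from compound 3 to compound 4 (beyond the scatter) in this assay, so a second aryl group besides the 4-fluorophenyl of compound 1 clears the scatter over methyl, which the 4-chloro-2-fluorophenyl of compound 2 did not do. The other two steps, a number 6 percentage points higher from compound 2 to compound 4 (within the scatter) and a number 18 percentage points lower from compound 1 to compound 4 (beyond the scatter), show that compound 4 cannot be told apart from compound 2 and that compound 1 stays ahead of the other aryl compounds. Nothing measured here explains why these aryl groups differ.

Still open, as far as these compounds go, is whether plain phenyl or 4-bromophenyl on this nitrogen would reach the number of compound 1. Also open, from the compounds shown here alone, is whether a group without an aryl ring, such as a longer alkyl chain or a carboxylic acid, would rise above methyl.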